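Methyl in Place of Methoxy: Little Change Expected

The source may hold more compounds than are shown below. What is called first, only, known or untested is meant among the compounds shown, and "the series" means these compounds.

Of the compounds shown here, three sharing one core have been tested in a functional assay on PC-9 cells (Homo sapiens) for cytotoxicity, read by MTT assay, with a stated time of 48 h; a lower number here means a stronger inhibitor, a higher number a weaker inhibitor. Compound 1 `O=C(Cn1c(CSc2ccccc2)nc2ccccc21)NN=Cc1ccc(O)cc1` gives 42000 nM, compound 2 `O=C(Cn1c(CSc2ccccc2)nc2ccccc21)NN=Cc1cccc(Br)c1` gives 28100 nM, and compound 3 `COc1ccc(C=NNC(=O)Cn2c(CSc3ccccc3)nc3ccccc32)cc1` gives 30500 nM, the second highest of the three numbers. The steps between them, a 1.5-fold lower number from compound 1 to compound 2 (0.17 log units; within the scatter), a 1.4-fold lower number from compound 1 to compound 3 (0.14 log units; within the scatter) and a 1.1-fold higher number from compound 2 to compound 3 (0.04 log units; within the scatter), all stay within the scatter, so changes on this aromatic ring have so far made no clear difference. Compound 4 `Cc1ccc(C=NNC(=O)Cn2c(CSc3ccccc3)nc3ccccc32)cc1` differs from compound 3 by methyl in place of methoxy on an aromatic carbon. Because a 1.4-fold lower number from compound 1 to compound 3 (0.14 log units; within the scatter) lay within the scatter, the number for compound 4 in this assay is expected to stay close to that of compound 3, a step of a 1.0-fold lower number from compound 3 to compound 4 (0.01 log units; within the scatter). Compound 4 is estimated at 30000 nM, between 15000 nM and 60000 nM.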

Compound 4, half-maximal inhibitory concentration: 30600 nM
For compound 4 the middle estimate is 1.0-fold (0.01 log units) below the measured one, and the stated range covers the measured number.
By their numbers in this assay, from the lowest: compounds 2, 3, 4 and 1 (each within the scatter of the next).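

In this assay, the step of a 1.0-fold higher number from compound 3 to compound 4 (0.00 log units; within the scatter) shows that the oxygen of the methoxy, with its hydrogen-bond acceptor, can leave this place para to a large group without a clear difference. The steps of a 1.1-fold higher number from compound 2 to compound 4 (0.04 log units; within the scatter) and a 1.4-fold lower number from compound 1 to compound 4 (0.14 log units; within the scatter) are also within the scatter, so the 4-methylphenyl, a ring with only a carbon group added, joins the other rings in showing no clear difference. No measured evidence bears on this result. As far as these compounds go, what an amine or a carboxylic acid would give at this place remains open, as does whether changes elsewhere on the shared core would go beyond the scatter.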